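This account rests on a few compounds, and the source may have more. Where it says the series, first, only, none or still open, it means among the compounds named here.

Compound 2 `COc1cc(OC)c(-c2coc3cc(OCc4ccc(F)cc4)ccc3c2=O)cc1OC` gives 1720 nM in a functional assay on A-375 cells (Homo sapiens) for antiproliferative activity, read by MTT assay, with a stated time of 24 h; on this read-out higher numbers stand for weaker inhibition and lower numbers for stronger inhibition. Compound 1 `COc1cc(OC)c(-c2coc3cc(OCc4ccccc4)ccc3c2=O)cc1OC` gives 1640 nM, and compound 3 `COc1cc(OC)c(-c2coc3cc(OCc4ccc(Br)cc4)ccc3c2=O)cc1OC` gives 1000 nM; compound 2 sits within the usual scatter of both, so no ordering among the three can be claimed. Compound 4 `COc1cc(OC)c(-c2coc3cc(OCc4ccccc4Br)ccc3c2=O)cc1OC` is the next compound: 2-bromophenyl in place of 4-fluorophenyl on a saturated chain carbon bound to an oxygen on an aromatic ring. The measured step closest to this change is a 1.7-fold lower number from compound 2 to compound 3 (0.24 log units; within the scatter), where bromine also replaced fluorine, though at a different position; a 1.0-fold higher number from compound 1 to compound 2 (0.02 log units; within the scatter) and a 1.6-fold lower number from compound 1 to compound 3 (0.21 log units; within the scatter) likewise stayed within the scatter. Among the measured compounds shown here, no measured compound carries bromine at the new position, so only a small step is expected, a 1.3-fold lower number from compound 2 to compound 4 (0.12 log units; within the scatter). Compound 4 is therefore estimated at 1300 nM, with a range from 550 nM to 3100 nM.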

Compound 4, half-maximal inhibitory concentration: 2850 nM
Compound 4: the middle estimate sits 2.2-fold (0.34 log units) below what was measured; the range from low to high includes it.
By their numbers in this assay, from the lowest: compounds 3, 1, 2 and 4 (each within the scatter of the next, the first and the last beyond it).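

In this assay, among the compounds shown here, moving the bromine alone gives the first step beyond the usual scatter: 2-bromophenyl in place of 4-bromophenyl gives a 2.9-fold higher number from compound 3 to compound 4 (0.45 log units; beyond the scatter) on the same chain carbon. The other two comparisons stay within the scatter, with a 1.7-fold higher number from compound 1 to compound 4 (0.24 log units; within the scatter) and a 1.7-fold higher number from compound 2 to compound 4 (0.22 log units; within the scatter) here. No evidence is available to explain the gap between the two bromine placements. The compounds shown leave open whether a 2-methoxyphenyl or 2-aminophenyl group would give a number like that of the 2-bromophenyl compound.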